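The source may report more compounds than this note shows. Statements on the series, on what has been measured and on what is new or still open speak of the compounds shown alone.

Compound 1 `CN1CCC(Cn2nc(Cc3ccc(Cl)cc3)c3ccccc3c2=O)C1` shows the lowest of the two numbers available in an assay for binding affinity to Alpha-1A adrenergic receptor (Homo sapiens); on this read-out lower numbers stand for stronger inhibition and higher numbers for weaker inhibition; in this assay compound 1 gives 100 nM. Compound 2 `COc1ccc(Cc2nn(C[C@H]3CCCN3C)c(=O)c3ccccc23)cc1` sits close by: in this assay compound 2 gives 126 nM, a gap within the scatter, so no order between the two is claimed. Compound 3 `CN1CCCC1CCn1nc(Cc2ccc(Cl)cc2)c2ccccc2c1=O` carries (1-methylpyrrolidin-2-yl)methyl in place of 1-methylpyrrolidin-3-yl on a saturated chain carbon bound to an aromatic nitrogen. Among the measured compounds shown here, no measured step of this kind is at hand, so the size of the change remains uncertain; a modest weakening, possibly just beyond the scatter, is expected, a 1.7-fold higher number from compound 1 to compound 3 (0.23 log units; within the scatter). For compound 3 the expected inhibition constant is 170 nM, with a range from 60 nM to 480 nM.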

Compound 3, inhibition constant: 316 nM
Compound 3: middle estimate off by 1.9-fold (0.27 log units), on the low side, and the stated range covers the measured number.
By their numbers in this assay, from the lowest: compounds 1 and 2 (each within the scatter of the next); then compound 3.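

In this assay, among the compounds shown here, (1-methylpyrrolidin-2-yl)methyl in place of 1-methylpyrrolidin-3-yl gives a 3.2-fold higher number from compound 1 to compound 3 (0.50 log units; beyond the scatter) and thus the first measured step on this saturated chain carbon bound to an aromatic nitrogen. The position therefore responds to this change, though the step is modest. Nothing at hand explains the step.

As far as these compounds go, the step changes the pyrrolidine attachment point and the carbon count together, so their separate contributions remain open. Also open, from the compounds shown here alone, is how a piperidine or an open-chain dimethylamino group would read here in this assay on the core of compound 1.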